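Trading the Neopentyl Arm of Compound 3 for a Phenyl Amide

This account rests on a few compounds, and the source may have more. Where it says the series, first, only, none or still open, it means among the compounds named here.

Three compounds sharing one core were compared in an assay on CHO cells with Substance-P receptor (Homo sapiens) as the target; a higher number here means a weaker inhibitor, a lower number a stronger inhibitor. Compound 1 `CC(C)N1CCN(C(=O)CCc2c(-c3ccc(Cl)cc3)n(C)c3ccc(Cl)cc23)CC1` gives 13 nM, compound 2 `Cn1c(-c2ccc(Cl)cc2)c(CCC(=O)N2CCN(C3CCCCC3)CC2)c2cc(Cl)ccc21` gives 0.35 nM, and compound 3 `Cn1c(-c2ccc(Cl)cc2)c(CCC(=O)N2CCN(CC(C)(C)C)CC2)c2cc(Cl)ccc21` gives 2 nM, the second highest of the three numbers. The steps of a 6.5-fold lower number from compound 1 to compound 3 (0.81 log units; beyond the scatter) and a 5.7-fold higher number from compound 2 to compound 3 (0.76 log units; beyond the scatter) show that the group on the amine nitrogen in the ring shifts the result by modest amounts. Compound 4 `CN(C(=O)CN1CCN(C(=O)CCc2c(-c3ccc(Cl)cc3)n(C)c3ccc(Cl)cc23)CC1)c1ccccc1` differs from compound 3 by methyl(phenyl)carbamoyl in place of tert-butyl on a saturated chain carbon bound to an amine nitrogen in a ring. For the measured compounds named here, none of the measured steps introduces a carbonyl or an aromatic ring at that place, so only the spread among compounds 1, 2 and 3 guides the expectation. Compound 4 is expected to show a 2.5-fold higher number from compound 3 to compound 4 (0.40 log units; beyond the scatter) in this assay. The estimate for compound 4 is 5 nM, between 1 nM and 30 nM.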

Compound 4, half-maximal inhibitory concentration: 0.13 nM
Compound 4: the middle estimate sits 38-fold (1.59 log units) above what was measured, outside the stated range (below it).
By their numbers in this assay, from the lowest: compound 4; then compound 2; then compound 3; then compound 1.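

In this assay the change brings a 15-fold lower number from compound 3 to compound 4 (1.19 log units; beyond the scatter) and a 2.7-fold lower number from compound 2 to compound 4 (0.43 log units; beyond the scatter) and a 100-fold lower number from compound 1 to compound 4 (2.00 log units; beyond the scatter) at this amine nitrogen in a ring, so compound 4 is the strongest inhibitor of the four. The position therefore accepts a much larger arm carrying a carbonyl and an aromatic ring, and this arm surpasses cyclohexyl, the best of the simple carbon groups. Nothing measured here explains this gain.

Whether the carbonyl or the phenyl ring accounts for the gain remains open. So does whether a benzyl group, or a longer chain bearing the same amide, would keep it.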